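Swapping an acid for a propyl chain: toxicity expectation

This account rests on a few compounds, and the source may have more. Where it says the series, first, only, none or still open, it means among the compounds named here.

Measured compounds in a toxicity assay on MDCK cells (Canis lupus familiaris) for cytotoxicity, read by crystal violet staining, with a stated time of 48 h; on this read-out lower numbers stand for higher toxicity in this test and higher numbers for lower toxicity in this test:
Compound 1 `Cc1ccc2[nH]c(=O)c(CN(Cc3ccccc3)Cc3ccc(C(C)(C)C)cc3)cc2c1` gives > 5000 nM in this assay, a limit of the test rather than a number.
Compound 2 `Cc1ccc2[nH]c(=O)c(CN(Cc3ccc(OCC(=O)OC(C)(C)C)cc3)Cc3ccc(C(C)(C)C)cc3)cc2c1` gives > 10000 nM in this assay, again a limit.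
Compound 3 `Cc1ccc2[nH]c(=O)c(CN(Cc3ccc(OCC(=O)O)cc3)Cc3ccc(C(C)(C)C)cc3)cc2c1` gives > 10000 nM in this assay, also a limit.

Compound 3 therefore stands only at a limit, and the two other values are limits as well. The steps from compound 1 to compound 2 a step that the two limits leave unreadable from compound 1 to compound 2, from compound 1 to compound 3 a step that the two limits leave unreadable from compound 1 to compound 3 and from compound 2 to compound 3 a step that the two limits leave unreadable from compound 2 to compound 3 cannot be sized, since the limit of > 10000 nM in this assay, at which 2 of the 3 values shown sit, and the limit of > 5000 nM in this assay, at which 1 of the 3 values shown sits, cap every value.

Compound 4 `CCCCOc1ccc(CN(Cc2ccc(C(C)(C)C)cc2)Cc2cc3cc(C)ccc3[nH]c2=O)cc1` differs from compound 3 by propyl in place of carboxy on a saturated chain carbon bound to an oxygen on an aromatic ring. For the measured compounds named here, no measured step tells how this change acts, and the change most like it, from compound 2 to compound 3, is itself unreadable. The expectation for compound 4 in this assay is therefore the step of a number no higher from compound 3 to compound 4 (the limit leaves the size open), most likely a value at or beyond the limit again. Compound 4 is estimated at 10000 nM, between 3000 nM and 30000 nM.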

Compound 4, half-maximal cytotoxic concentration: > 5000 nM
Compound 4 was reported as a limit; the forecaster's own chance of this, stated with the estimate: 75%; the middle value does not contradict the limit.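

Compound 4 also stands at a limit of the test, so its steps from compound 1, compound 2 and compound 3 cannot be read: the limit of > 5000 nM in this assay, at which 2 of the 4 values shown sit.

On these data alone, the actual half-maximal cytotoxic concentrations of all four compounds in this assay stay open, and so does whether propyl in place of carboxy shifts them at all.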